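The source may report more compounds than this note shows. Statements on the series, on what has been measured and on what is new or still open speak of the compounds shown alone.

Compound 1 `COc1ccc(-c2cn(C)c(NC(=O)c3ccc(F)cc3)n2)cc1`: in a toxicity assay on THP-1 cells (Homo sapiens) for inhibition (on this read-out higher numbers stand for lower toxicity in this test and lower numbers for higher toxicity in this test), compound 1 gives > 50000 nM, which is a limit of the test and not a number.
Compound 2 `Cc1ccccc1-c1cnc(NC(=O)c2ccc(F)cc2)n1C`: in this assay compound 2 gives > 50000 nM, again only a limit.
Compound 3 `COc1ccc(-c2cnc(NC(=O)c3ccc(F)cc3)[nH]2)cc1`: in this assay compound 3 gives > 100000 nM, also a limit.

Compound 2 thus stands at a limit, and the other two values shown are limits as well: the limit of > 50000 nM in this assay, at which 2 of the 3 values shown sit, and (the limit of > 100000 nM in this assay, at which 1 of the 3 values shown sits). Among the compounds with values here, no step between measured compounds can be sized from these data. Compound 4 `Cn1c(-c2ccccc2Br)cnc1NC(=O)c1ccc(F)cc1` differs from compound 2 by bromo in place of methyl on an aromatic carbon. Within the data shown here, since every value so far in this assay sits at a limit, the step from compound 2 to compound 4 is expected to be none beyond the scatter, a step that the limit leaves unreadable from compound 2 to compound 4. Compound 4 is accordingly estimated at 60000 nM, within 25000 nM to 150000 nM, most likely reported once more only as a limit.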

Compound 4, half-maximal cytotoxic concentration: > 100000 nM
Compound 4 gave a limit, no number; the forecaster's own chance of this, stated with the estimate: 80%; middle value at least 1.6-fold (0.22 log units) away from the limit.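

No step can be read between compound 2 and compound 4 in this assay: both values are limits. The compounds shown leave open at what concentration any of them would give a measurable toxic effect in this assay.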